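Sulfone side chain trimming and kinetic solubility in the series

A few compounds are considered here, and "the series" means these few. Any claim that something is new, unique, unknown or untested is made for them only; others in the source may bear on it.

Three compounds are measured in a physicochemical assay for solubility, in phosphate buffer, measured as kinetic solubility, with a stated time of 1 h, at pH 7.4 (on this read-out higher numbers stand for higher solubility and lower numbers for lower solubility), and a fourth is not yet measured. Compound 1 `CNCC(=O)Nc1ccc(-c2nc(C(C)(C)S(C)(=O)=O)cc([C@]34CCOC[C@H]3C4)n2)cc1` stands highest of the three; in this assay compound 1 gives 217 ug/mL. Compound 2 `CCNC(=O)Nc1ccc(-c2nc(C(C)(C)S(C)(=O)=O)cc([C@@]34CCOC[C@@H]3C4)n2)cc1` gives 78 ug/mL in this assay, and compound 3 `CCNC(=O)Nc1ccc(-c2nc(CS(C)(=O)=O)cc([C@@]34CCOC[C@@H]3C4)n2)cc1` gives 77 ug/mL. The difference between the core of compound 1 and the core of compound 2 is not broken down here; the two share the same atoms, joined differently.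

Compound 2 and compound 3 differ in one place, ((methylsulfonyl)methyl in place of 1-methyl-1-(methylsulfonyl)ethyl on an aromatic carbon). The step in this assay was a 1.0-fold lower number from compound 2 to compound 3 (0.01 log units; within the scatter), so within this pair the shorter sulfone side chain left the read-out essentially unchanged.

Compound 4 `CNCC(=O)Nc1ccc(-c2nc(CS(C)(=O)=O)cc([C@]34CCOC[C@H]3C4)n2)cc1` carries the same change relative to compound 1: (methylsulfonyl)methyl in place of 1-methyl-1-(methylsulfonyl)ethyl on an aromatic carbon. Going by the values given here, the place description matches the one for the change from compound 2 to compound 3 word for word, so the two are taken as the same change made on two cores. Since the measured step was a 1.0-fold lower number from compound 2 to compound 3 (0.01 log units; within the scatter), the expected step from compound 1 to compound 4 in this assay is a 1.1-fold lower number from compound 1 to compound 4 (0.04 log units; within the scatter), resting on that single measured pair alone; the two cores are not identical, which leaves room for a different outcome. For compound 4 in this assay a value of about 200 ug/mL is expected, most likely between 100 ug/mL and 400 ug/mL.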

Compound 4, solubility: 158 ug/mL
The estimate for compound 4 lay 1.3-fold (0.10 log units) above the measured number, and the stated range covers the measured number.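

In this assay, the swap of 1-methyl-1-(methylsulfonyl)ethyl for (methylsulfonyl)methyl gives a 1.4-fold lower number from compound 1 to compound 4 (0.14 log units; within the scatter), and on the other core the same swap gives a 1.0-fold lower number from compound 2 to compound 3 (0.01 log units; within the scatter), so in both measured pairs the step stays inside the usual scatter of the read-out and the result from one core carried over to the other. This is agreement between just two matched pairs: it shows that the change can be carried between these two cores without a step beyond the scatter, but it does not establish a rule for other cores in the series, nor does it show that a small real effect is absent, since such an effect could be hidden in the scatter. No measurement at hand explains why the read-out behaves this way on either core.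

The compounds shown leave open what happens on the same aromatic carbon with a longer chain, such as 3-(methylsulfonyl)propyl, or with a group that has no sulfone at all, such as a carboxylic acid or an amine. They also leave open whether the swap behaves the same way on any core beyond the two seen here.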